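Resorcinol isoxazole amides: pyrazole replacement at the aryl position

This account rests on a few compounds, and the source may have more. Where it says the series, first, only, none or still open, it means among the compounds named here.

Measured so far:
- compound 1 `CCNC(=O)c1noc(-c2cc(C(C)C)c(O)cc2O)c1-c1cc(CNC(C)C)no1`: 38 nM in a functional assay on A2780 cells (Homo sapiens) for inhibition; a lower number here means a stronger inhibitor, a higher number a weaker inhibitor
- compound 2 `CCNC(=O)c1noc(-c2cc(C(C)C)c(O)cc2O)c1-c1cc(CNC(C)=O)no1`: "not determined" (no result reported) in this assay

Compound 2 stands at "not determined" (no result reported), so it gives no number; the only anchor in this assay is compound 1 with 38 nM. Compound 3 `CCNC(=O)c1noc(-c2cc(C(C)C)c(O)cc2O)c1-c1ccn(C)n1` differs from compound 2 by the change (1-methyl-1H-pyrazol-3-yl in place of 3-(acetamidomethyl)-1,2-oxazol-5-yl on an aromatic carbon). Among the measured compounds shown here, no step between measured compounds is available, so the size of the change cannot be calibrated; a step of modest size in either direction, possibly not beyond the scatter, is expected. Compound 3 is estimated at 100 nM in this assay, within a range of 30 nM to 400 nM.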

Compound 3, half-maximal inhibitory concentration: 12 nM
The estimate for compound 3 lay 8.3-fold (0.92 log units) above the measured number; measured number below the stated range.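

In this assay, 1-methyl-1H-pyrazol-3-yl in place of 3-((isopropylamino)methyl)-1,2-oxazol-5-yl gives a 3.2-fold lower number from compound 1 to compound 3 (0.50 log units; beyond the scatter), so a number this low at this position on the shared core does not depend on the isopropylamino side chain. The step from compound 2 to compound 3 cannot be read, since compound 2 has no number. Nothing available bears on the reason for this step.

Open, as far as these compounds go, is whether an ethyl group or a hydrogen on the pyrazole nitrogen would hold this level. Also open, from the compounds shown here alone, is whether an aminomethyl chain on the pyrazole would shift it.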